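A few compounds are considered here, and "the series" means these few. Any claim that something is new, unique, unknown or untested is made for them only; others in the source may bear on it.

Measured so far:
- compound 1 `COc1ccc(/C=C/c2ccc3ccccc3c2)cc1N`: > 5000 nM, a limit
- compound 2 `COc1cc(/C=C/c2ccc3ccccc3c2)cc(N)c1OC`: 6000 nM
- compound 3 `COc1cc(/C=C/c2ccc3ccccc3c2)cc(NC(C)=O)c1OC`: > 5000 nM, a limit

Within the data shown here, in a functional assay on HT-29 cells (Homo sapiens) for inhibition (a lower number here means a stronger inhibitor, a higher number a weaker inhibitor), compound 2 gives 6000 nM, the only true number of the three, and it lies close to the limit of > 5000 nM in this assay, at which 2 of the 3 values shown sit. Compound 4 `COc1c(N)cc(/C=C/c2ccc3ccccc3c2)cc1N` differs from it by amino in place of methoxy on an aromatic carbon, ortho to a methoxy group. Among the measured compounds shown here, two measured steps touch compound 2, a step that the limit leaves unreadable from compound 1 to compound 2 and a step that the limit leaves unreadable from compound 2 to compound 3. Neither exchanges methoxy for amino, and neither has a readable size. No direction can therefore be drawn from them for this assay, and the expected change is no change at the digits printed from compound 2 to compound 4 (within the scatter), none beyond the scatter. For compound 4 the estimate is 6000 nM, with an expected range of 2000 nM to 15000 nM.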

Compound 4, half-maximal inhibitory concentration: > 5000 nM
Compound 4 ended at the assay's limit (the forecaster's own chance of this, stated with the estimate: 50%); the middle value is on the limit's open side.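

Among these compounds, no step to compound 4 can be read, from compound 2 or from compound 1, because compound 4 also stands at a limit: the limit of > 5000 nM in this assay, at which 3 of the 4 values shown sit. The compounds shown leave open whether amino in place of methoxy on an aromatic carbon changes inhibition in this assay at all.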